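The source may hold more compounds than are shown below. What is called first, only, known or untested is meant among the compounds shown, and "the series" means these compounds.

Measured compounds:
Compound 1, `ClCc1ccc(Cn2cnc3c(Cl)ncnc32)cc1`, in a functional assay on NCI-H23 cells (Homo sapiens) for cytotoxicity, read by sulforhodamine B assay, with a stated time of 48 h (a lower number here means a stronger inhibitor of growth, a higher number a weaker inhibitor of growth), gives 2450 nM.
Compound 2, `ClCc1ccccc1Cn1cnc2c(Cl)nc(Cl)nc21`, in this assay gives 3090 nM.

Compound 2 has the higher of the two numbers, but compound 1 stands close to it, and the gap between the two lies within the usual scatter, so the two cannot be told apart on these figures.

Compound 3, `ClCc1ccccc1Cn1cnc2c(Cl)ncnc21`, has not yet been measured in this assay. It differs from compound 2 in one place: hydrogen in place of chloro on an aromatic carbon. Compound 2 therefore carries two chloro groups on its core where compound 3 carries one.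

Among the compounds with values here, no pair of measured compounds differs in a single place, so no measured step can guide this change. Within the data shown here, what is known is only that compound 1 and compound 2 sit within the scatter of each other. On that basis the step from compound 2 to compound 3 is expected to be small, with no clear direction beyond the scatter, and is estimated as a 1.1-fold lower number from compound 2 to compound 3 (0.04 log units; within the scatter). Compound 3 is accordingly estimated at 2800 nM, with a range from 1000 nM to 8000 nM.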

Compound 3, concentration for total growth inhibition: 4360 nM
Compound 3: middle estimate off by 1.6-fold (0.19 log units), on the low side; measured number inside the range.
By their numbers in this assay, from the lowest: compounds 1, 2 and 3 (each within the scatter of the next).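

Within the data shown here, with hydrogen in place of chloro on the aromatic carbon between two ring nitrogen atoms, this assay shows a 1.4-fold higher number from compound 2 to compound 3 (0.15 log units; within the scatter), the only step here that isolates a single change, and it places this position under direct test for the first time. Compound 2 and compound 3 therefore cannot be told apart on these figures, and the chloro group at this position shows no measurable contribution to the read-out beyond the scatter, even though it is the one heavy atom that leaves in this change. Nothing at hand bears on what lies behind this result, so the step stands as an observation alone.

The compounds shown compare only chloro and hydrogen at this position, so it remains open whether an amine or a methoxy group on the same carbon would give a step beyond the scatter. Also open, as far as these compounds go, is how the number would respond if the remaining chloro group, which stands meta to this carbon, gave way to hydrogen or to an amine.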